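This account rests on a few compounds, and the source may have more. Where it says the series, first, only, none or still open, it means among the compounds named here.

Measured so far:
Compound 1 `Cc1ccc(-n2cc(C(=O)Nc3cc(F)cc(F)c3)c(=O)c3ccc(N(C)C)nc32)cc1OCCCCCCC[N+]12CCN(CC1)CC2` — 9.71%
Compound 2 `CN(C)c1ccc2c(=O)c(C(=O)Nc3cc(F)cc(F)c3)cn(-c3ccc(Cl)c(OCCCCCCC[N+]45CCN(CC4)CC5)c3)c2n1` — 18.7%

Among the compounds with values here, in an assay on LX2 cells for inhibition of COL1A1 promoter (Homo sapiens), read by a luciferase reporter, with a stated time of 24 h, tested at 50 uM (on this read-out higher numbers stand for a stronger effect at the one concentration tested and lower numbers for a weaker effect), compound 1 gives 9.71%, the lower of the two numbers recorded; its only neighbour is compound 2, and the step of a number 9 percentage points higher from compound 1 to compound 2 (within the scatter) lies within the scatter, so the two compounds cannot be ordered.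

Compound 3 `Cc1ccc(-n2cc(C(=O)Nc3cc(F)cc(F)c3)c(=O)c3ccc(N(C)C)nc32)cc1OCCCCCCC[N+]1(C)CCN(C)CC1` differs from compound 1 by a group of 8 heavy atoms (6 carbon, 2 nitrogen; one six-membered non-aromatic ring with 2 hetero atoms) in place of a group of 8 heavy atoms (6 carbon, 2 nitrogen; 2 six-membered non-aromatic rings with 2 hetero atoms each), on a saturated chain carbon, seven bonds along the chain from an oxygen on an aromatic ring. Within the data shown here, no measured step concerns this position: the one known step, chloro in place of methyl on an aromatic carbon, a number 9 percentage points higher from compound 1 to compound 2 (within the scatter), touches the aromatic ring and not the chain end, and it is itself within the scatter. Among the measured compounds shown here, the step from compound 1 to compound 3 therefore has no precedent here, and with both measured numbers low, no move beyond the scatter is expected in this assay in either direction.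

Compound 3 is expected to give about 10%, in the range 0% to 25%. The expected step of a number 0.3 percentage points higher from compound 1 to compound 3 (within the scatter) stays within the scatter.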

Compound 3, a percentage reported as inhibition, at one concentration (the size of the read-out at that concentration, not a potency): 25%
Beside the measured number, compound 3's estimate is 15 percentage points below it, and the stated range covers the measured number.
By their numbers in this assay, from the lowest: compounds 1, 2 and 3 (each within the scatter of the next, the first and the last beyond it).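

At the chain end, seven bonds along the chain from an oxygen on an aromatic ring, replacing the group with 2 six-membered non-aromatic rings by the group with one such ring gives a number 15.3 percentage points higher from compound 1 to compound 3 (beyond the scatter) in this assay. This is the only position here with a step beyond the scatter, though the step is modest. Both groups have 8 heavy atoms and a net charge of +1, and nothing available bears on why the exchange changes the read-out.

Still open, on these data alone, is whether a morpholine or a trimethylammonium group at the chain end, or a shorter or longer chain, would give a larger effect. As far as these compounds go, it is also open whether the same exchange on the chloro-bearing compound 2 gives a step of similar size, and whether a potency measurement would follow this single-concentration read-out.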